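Second sulfonamide arm on the core of compound 2

A few compounds are considered here, and "the series" means these few. Any claim that something is new, unique, unknown or untested is made for them only; others in the source may bear on it.

Compound 1 `O=S(=O)(Nc1ccc(-c2nc3ccccc3o2)cc1)c1cccc(F)c1` gives 71000 nM in an assay on cells for inhibition of HSP60/HSP10 (Homo sapiens), with a stated time of 60 min; a higher number here means a weaker inhibitor, a lower number a stronger inhibitor. Compound 2 `O=S(=O)(Nc1ccc(-c2nc3ccccc3o2)cc1)c1cccc(O)c1` gives 62000 nM in this assay; the step of a 1.1-fold lower number from compound 1 to compound 2 (0.06 log units; within the scatter) is hydroxy in place of fluoro on an aromatic carbon. Going by the values given here, on the numbers so far compound 2 holds the lowest of the two, with compound 1 as its nearest neighbour at a gap within the scatter, so neither can be called the stronger. Compound 3 `O=S(=O)(Nc1ccc(-c2nc3cc(NS(=O)(=O)c4cccc(O)c4)ccc3o2)cc1)c1cccc(O)c1` carries the change (((3-hydroxyphenyl)sulfonyl)amino in place of hydrogen on an aromatic carbon). Among the compounds with values here, the one measured step swaps a small substituent for another and says nothing about attaching a second arm of this size, so no measured step bears on the change to compound 3. The expectation for this assay rests on compound 2 alone and must be wide. For compound 3 the estimated step is a 1.4-fold lower number from compound 2 to compound 3 (0.14 log units; within the scatter). Compound 3 is expected to give 45000 nM in this assay, within 12000 nM to 150000 nM.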

Compound 3, half-maximal inhibitory concentration: 17000 nM
For compound 3 the middle estimate is 2.6-fold (0.42 log units) above the measured one; low and high end bracket the measured number.
By their numbers in this assay, from the lowest: compound 3; then compounds 2 and 1 (each within the scatter of the next).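

In this assay, going by these compounds alone, placing ((3-hydroxyphenyl)sulfonyl)amino on this aromatic carbon of the fused two-ring system gives a 3.6-fold lower number from compound 2 to compound 3 (0.56 log units; beyond the scatter) and is the first modest change to exceed the scatter. The earlier swap on the outer ring, a 1.1-fold lower number from compound 1 to compound 2 (0.06 log units; within the scatter), could not separate its two compounds, so this carbon of the shared core is the first position shown to respond, and it accepts an arm of this size without any loss. Nothing available accounts for the gain.

Only one group is shown at this carbon, so it remains open whether a small amine or a carboxylic acid there would give a similar step. From the compounds shown here alone, it is also open whether the step needs the whole arm, including its hydroxy.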